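A few compounds are considered here, and "the series" means these few. Any claim that something is new, unique, unknown or untested is made for them only; others in the source may bear on it.

Working notes on the series. Going by the values given here, compound 1 `CCN1CCc2c(sc(NC(=O)[C@@H]3CCCN3)c2C(N)=O)C1` is the first point of comparison. In a functional assay (strain AB) with Danio rerio as the target, read by microscopy, with a stated time of 1 h (a lower number here means that less compound is needed, a higher number that more compound is needed for the effect), compound 1 gives > 25000 nM, which is a limit of the assay and not a number. Compound 1 therefore stands at the edge of what this assay can read, because of the limit of > 25000 nM in this assay, at which 1 of the 2 values shown sits. Among the compounds with values here, compound 2 `CCN1CCc2sc(NC(=O)Nc3ccc(Cl)cc3)c(C(N)=O)c2CC1` is the second measured member of the set, and in this assay compound 2 gives 5800 nM; the two values show only that compound 2 reaches a number where compound 1 does not, and no step between the two is established.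

Compound 3 `CCN1CCc2c(sc(NC(=O)NCC3CCCO3)c2C(N)=O)C1` has not been measured. Set against compound 1 it shows (((oxolan-2-yl)methyl)amino in place of pyrrolidin-2-yl on a carbonyl carbon). Within the data shown here, no measured pair in the set follows a change of this kind, so nothing here gives the size of the step directly. The expectation is a small movement towards lower values, if any beyond the scatter, and it is held as an at least 1.2-fold lower number from compound 1 to compound 3 (0.09 log units; that floor lies within the scatter), judged as an estimate from compound 1 alone. Compound 3 is expected to give about 20000 nM in this assay, with a range from 6000 nM to 60000 nM, a limit again being a real possibility.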

Compound 3, half-maximal effective concentration: > 25000 nM
Compound 3: only a limit was reported; the forecaster's own chance of this, stated with the estimate: 55%; middle value at least 1.2-fold (0.09 log units) from the limit.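

No step from compound 1 to compound 3 can be read, because both compounds stand at the same limit of the assay, which is not a number: the limit of > 25000 nM in this assay, at which 2 of the 3 values shown sit.

The compounds shown leave open whether ((oxolan-2-yl)methyl)amino in place of pyrrolidin-2-yl on a carbonyl carbon moves the value in this assay at all, and in which direction.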